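From Methyl to tert-Butyl on the Aromatic Carbon

The source may hold more compounds than are shown below. What is called first, only, known or untested is meant among the compounds shown, and "the series" means these compounds.

Compound 1 `COc1cc(-c2ccnc3cc(-c4ccc(C)cc4)nn23)cc(OC)c1OC` gives 47 nM in a functional assay on MCF7 cells (Homo sapiens) for inhibition, read by CCK-8 assay, with a stated time of 48 h (a lower number here means a stronger inhibitor, a higher number a weaker inhibitor), the lowest of the two numbers seen. Compound 2 `COc1cc(-c2ccnc3cc(-c4ccc(-c5cnn(C)c5)cc4)nn23)cc(OC)c1OC` gives 274 nM in this assay, and the step of a 5.8-fold higher number from compound 1 to compound 2 (0.77 log units; beyond the scatter) shows that exchange raised the number. Compound 3 `COc1cc(-c2ccnc3cc(-c4ccc(C(C)(C)C)cc4)nn23)cc(OC)c1OC` differs from compound 1 by tert-butyl in place of methyl on an aromatic carbon. Within the data shown here, no measured step covers tert-butyl itself; the only comparison, a 5.8-fold higher number from compound 1 to compound 2 (0.77 log units; beyond the scatter), concerns a different replacement at the same position. Compound 3 is therefore expected to show a modest step upward, a 2.3-fold higher number from compound 1 to compound 3 (0.37 log units; beyond the scatter). Compound 3 is estimated at 110 nM, with a range from 35 nM to 400 nM.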

Compound 3, half-maximal inhibitory concentration: > 10000 nM
Compound 3 gave a limit, no number; the forecaster's own chance of this, stated with the estimate: 3%; at least 90-fold (1.95 log units) between middle value and limit.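

In this assay compound 3 gives only a limit, not a number: the limit of > 10000 nM in this assay, at which 1 of the 3 values shown sits. Replacing methyl with tert-butyl on this aromatic carbon gives an at least 210-fold higher number from compound 1 to compound 3 (2.32 log units; beyond the scatter), and the exchange from the pyrazole group gives an at least 36-fold higher number from compound 2 to compound 3 (1.56 log units; beyond the scatter). The position therefore tolerates one replacement far better than the other, so the result depends on which group enters, and not merely on the loss of methyl.

The compounds shown leave open whether ethyl or isopropyl at this position would stand nearer to compound 1 or to compound 3. They also leave open where an amine would fall.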